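A few compounds are considered here, and "the series" means these few. Any claim that something is new, unique, unknown or untested is made for them only; others in the source may bear on it.

The series shares one core, seen in compound 1 `O=C(CCl)Nn1c(S)nnc1COc1ccccc1C1=NOC(c2ccc(Cl)cc2Cl)C1`, which in an ADME assay (MDM cells, Homo sapiens) for cytotoxicity, read by resazurin assay, with a stated time of 3 days (a higher number here means a weaker inhibitor, a lower number a stronger inhibitor), gives 3.2 ug/mL. Compound 2 `O=C(CCl)Nn1c(COc2ccccc2C2=NOC(c3ccc(Cl)cc3Cl)C2)nnc1Sc1ccccc1` carries a phenylsulfanyl group on that core; in this assay compound 2 returned "not determined" (no result reported). Within the data shown here, compound 3 `C=CCSc1nnc(COc2ccccc2C2=NOC(c3ccc(Cl)cc3Cl)C2)n1NC(=O)CCl`, the allylsulfanyl member, likewise returned "not determined" (no result reported) in this assay, so compound 3 stands without a number of its own, and the only figure in this group is the one that compound 1 supplies.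

Compound 4 `CCCCSc1nnc(COc2ccccc2C2=NOC(c3ccc(Cl)cc3Cl)C2)n1NC(=O)CCl` differs from compound 3 in a single place: propyl in place of vinyl on a saturated chain carbon bound to a sulfur. Among the measured compounds shown here, no measured pair in this set brackets that change, so the size of the step from compound 3 to compound 4 in this assay cannot be read from the data; a step no larger than the usual scatter is expected, in either direction. Resting on the value of compound 1 3.2 ug/mL as the only anchor, compound 4 is estimated to give about 4 ug/mL in this assay, with a likely range from 1.5 ug/mL to 12 ug/mL.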

Compound 4, half-maximal inhibitory concentration: 2.8 ug/mL
Compound 4: middle estimate off by 1.4-fold (0.15 log units), on the high side, within the range that was stated.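

In this assay, butyl in place of hydrogen on the sulfur gives a 1.1-fold lower number from compound 1 to compound 4 (0.06 log units; within the scatter), so this position accepts a saturated four-carbon chain with no step beyond the scatter. Among these compounds, compound 4 thus supplies the first number for a group on this sulfur, while the steps involving compound 2 and compound 3 cannot be read, so the change from allylsulfanyl to butylsulfanyl stays without a size. No measured evidence bears on this result.

With only hydrogen and butyl compared, two points cannot show whether the number would hold for a chain longer than butyl or for a butyl chain ending in an amine or a carboxylic acid. From the compounds shown here alone, how a phenylsulfanyl or allylsulfanyl group compares with butylsulfanyl also remains open.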